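The source may report more compounds than this note shows. Statements on the series, on what has been measured and on what is new or still open speak of the compounds shown alone.

Compound 1 `COc1cc(/C=C2\CN(CC(=O)O)c3ccc(C)cc3C2=O)cc(OC)c1`: 23.8% in an assay on HL-60 cells for inhibition of glutathione S-transferase P (Homo sapiens), read by spectrophotometry, tested at 20 uM; on this read-out lower numbers stand for less inhibition and higher numbers for more inhibition at the one concentration tested (going by the name of the read-out). Compound 2 `COc1cccc(/C=C2\CN(CC(=O)O)c3ccc(C)cc3C2=O)c1`: 14.4%. Compound 3 `COc1cccc(/C=C2\CN(CC(=O)O)c3c(C)cccc3C2=O)c1OC`: 8.1%.

Compound 4 `COc1ccc(/C=C2\CN(CC(=O)O)c3c(C)cccc3C2=O)c(OC)c1OC` has not yet been measured. It is made from compound 3 by the change (methoxy in place of hydrogen on an aromatic carbon). The same kind of change is already measured once, from compound 2 to compound 1, where it is methoxy in place of hydrogen on an aromatic carbon; the surroundings differ, since in compound 1 the entering group sits meta to a large group and meta to a methoxy group, while in compound 4 it sits ortho to a methoxy group, meta to a methoxy group and para to a large group. That measured step is a number 9.4 percentage points higher from compound 2 to compound 1 (within the scatter). The difference between the core of compound 2 and the core of compound 3 is not broken down here; compound 3 stands lowest of the three, and only its gap to compound 1 reaches beyond the scatter.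

Resting on the step of a number 9.4 percentage points higher from compound 2 to compound 1 (within the scatter), compound 4 is expected to move from compound 3 by a number 5.9 percentage points higher from compound 3 to compound 4 (within the scatter), a step within the scatter. The estimate for compound 4 in this assay is therefore 14%, with a range from 3% to 27%.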

Compound 4, a percentage reported as inhibition, at one concentration (the size of the read-out at that concentration, not a potency): 1.57%
The estimate for compound 4 lay 12.4 percentage points above the measured number, and the stated range ends above it.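

In this assay, methoxy in place of hydrogen on an aromatic carbon did not behave as a fixed increment from one core to the other: the same change on two cores in this assay, a number 9.4 percentage points higher (within the scatter) from compound 2 to compound 1 and a number 6.5 percentage points lower (within the scatter) from compound 3 to compound 4, 15.9 percentage points apart, beyond the scatter of two such steps. The new step, a number 6.5 percentage points lower from compound 3 to compound 4 (within the scatter), does not by itself show that the methoxy lowers inhibition on this core, and the earlier step likewise does not show that it raises inhibition on the other. The gap between the two steps shows only that the result of this change cannot simply be transferred between these cores, and with a single pair for each core it does not show whether the core or the different place of the entering group accounts for that gap.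

The compounds shown leave open how a hydroxyl, a fluorine or an amine would compare with methoxy at these places on the aromatic ring. They also leave open whether an ester or an amide in place of the carboxylic acid would alter the readings.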